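Trimethoxyphenyl Swap on a Second Terpenoid Ester Core

The source may report more compounds than this note shows. Statements on the series, on what has been measured and on what is new or still open speak of the compounds shown alone.

Four compounds share a cinnamate-type ester attached to a terpenoid core, and their tolerance by liver-derived cells is followed in an ADME assay on HepG2 2.2.15 cells (Homo sapiens) for cytotoxicity, read by MTT assay; a lower number here means that less compound is tolerated, a higher number that more compound is tolerated. Compound 1 `C=C1CC[C@@H]2[C@](C)(COC(=O)/C=C/c3ccccc3)[C@H](O)CC[C@@]2(C)[C@@H]1/C=C/C1=CCOC1=O` carries a plain phenyl on the ester chain; in this assay compound 1 gives 183000 nM. Compound 2 `C=C1CC[C@@H]2[C@](C)(COC(=O)/C=C/c3cc(OC)c(OC)c(OC)c3)[C@H](O)CC[C@@]2(C)[C@@H]1/C=C/C1=CCOC1=O` differs from it by 3,4,5-trimethoxyphenyl in place of phenyl on a double-bonded chain carbon bound to a double-bonded chain carbon. For compound 2 this assay reports only a limit, > 1700000 nM, and so an at least 9.2-fold higher number from compound 1 to compound 2 (0.96 log units; beyond the scatter). The limit of > 1700000 nM in this assay, at which 1 of the 3 values shown sits, is the ceiling of what the assay can report, and compound 2 sits at it.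

Compound 3 `C=C1CC[C@@H]2[C@](C)(CO)[C@H](OC(=O)/C=C/c3ccccc3)CC[C@@]2(C)[C@@H]1C/C=C1\C=COC1=O` has the same atoms as compound 1 joined differently; the difference between the two cores is not broken down here. In this assay compound 3 gives 179000 nM, which lies within the scatter of the value of compound 1.

Compound 4 `C=C1CC[C@@H]2[C@](C)(CO)[C@H](OC(=O)/C=C/c3cc(OC)c(OC)c(OC)c3)CC[C@@]2(C)[C@@H]1C/C=C1\C=COC1=O` is not yet measured. It differs from compound 3 by 3,4,5-trimethoxyphenyl in place of phenyl on a double-bonded chain carbon bound to a double-bonded chain carbon, the same change that separates compound 1 from compound 2. Because an at least 9.2-fold higher number from compound 1 to compound 2 (0.96 log units; beyond the scatter) was at least modest and ended at the ceiling of the assay, the step from compound 3 to compound 4 is expected to be of similar size, a 9.5-fold higher number from compound 3 to compound 4 (0.98 log units; beyond the scatter). Compound 4 is therefore estimated at 1700000 nM, most likely reported again as a limit rather than a number, with a plausible range from 600000 nM to 3000000 nM.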

Compound 4, half-maximal cytotoxic concentration: 211000 nM
Estimate against measurement, compound 4: 8.1-fold (0.91 log units) above; measured number below the stated range.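

On the core of compound 3, putting 3,4,5-trimethoxyphenyl in place of phenyl gives a 1.2-fold higher number from compound 3 to compound 4 (0.07 log units; within the scatter) in this assay, so on this core the swap has no effect that can be told from the scatter. The same swap therefore does not carry over with the same size from one core to the other in this series: the same change on two cores in this assay, an at least 9.2-fold higher number (0.96 log units; beyond the scatter) from compound 1 to compound 2 and a 1.2-fold higher number (0.07 log units; within the scatter) from compound 3 to compound 4, at least 7.8-fold (0.89 log units) apart, beyond the scatter of two such steps This does not show which difference between the two cores lies behind the gap, nor the full size of the step on the core of compound 1, whose partner, compound 2, stands at a limit rather than a number: the limit of > 1700000 nM in this assay, at which 1 of the 4 values shown sits.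

From the compounds shown here alone, only one replacement for phenyl appears here, and it is tested on just two cores, so it remains open whether a ring carrying a single methoxy group, an amine or a carboxylic acid would also behave differently on the two cores. Also open, going by these compounds, is whether a longer chain in the ester would follow the pattern of compound 1 and compound 2 or that of compound 3 and compound 4.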